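This account rests on a few compounds, and the source may have more. Where it says the series, first, only, none or still open, it means among the compounds named here.

Measured in a functional assay on MCF7 cells (Homo sapiens) for cytotoxicity, read by MTT assay, with a stated time of 72 h; on this read-out lower numbers stand for stronger inhibition and higher numbers for weaker inhibition:
- compound 1 `COc1ccc(OC)c(/C=C/C(=O)Nc2cc3c(Nc4ccc(F)c(Cl)c4)ncnc3cc2OC)c1`: 34300 nM
- compound 2 `O=C(/C=C/c1cccc(Cl)c1Cl)Nc1cc2c(Nc3ccc(F)c(Cl)c3)ncnc2cc1O[C@H]1CCOC1`: 30100 nM
- compound 3 `N#Cc1ccc(/C=C/C(=O)Nc2cc3c(Nc4ccc(F)c(Cl)c4)ncnc3cc2O[C@H]2CCOC2)cc1`: 9830 nM

In this assay, compound 3 stands lowest of the three, beyond the scatter from both others. Compound 4 `COc1ccc(OC)c(/C=C/C(=O)Nc2cc3c(Nc4ccc(F)c(Cl)c4)ncnc3cc2O[C@H]2CCOC2)c1` differs from it in one place: 2,5-dimethoxyphenyl in place of 4-cyanophenyl on a double-bonded chain carbon bound to a double-bonded chain carbon. This puts 2,5-dimethoxyphenyl in place of 4-cyanophenyl on a double-bonded chain carbon bound to a double-bonded chain carbon. For the measured compounds named here, one measured step bears on this place: a 3.1-fold lower number from compound 2 to compound 3 (0.49 log units; beyond the scatter). Compound 1 also carries the 2,5-dimethoxyphenyl group and gives 34300 nM. A modest step to a higher number is therefore expected. The estimated step is a 2.4-fold higher number from compound 3 to compound 4 (0.39 log units; beyond the scatter). The expected value for compound 4 is 24000 nM, within an estimated range of 10000 nM to 55000 nM.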

Compound 4, half-maximal inhibitory concentration: 36300 nM
Estimate against measurement, compound 4: 1.5-fold (0.18 log units) below, within the range that was stated.
By their numbers in this assay, from the lowest: compound 3; then compounds 2, 1 and 4 (each within the scatter of the next).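

In this assay, 2,5-dimethoxyphenyl gives up what 4-cyanophenyl held at this place, a 3.7-fold higher number from compound 3 to compound 4 (0.57 log units; beyond the scatter), while it stands level with 2,3-dichlorophenyl, a 1.2-fold higher number from compound 2 to compound 4 (0.08 log units; within the scatter). Among these three groups, with oxolan-3-yl on the oxygen, only 4-cyanophenyl stands apart. The other place also gets its first reading: with 2,5-dimethoxyphenyl kept, oxolan-3-yl in place of methyl leaves the number level, a 1.1-fold higher number from compound 1 to compound 4 (0.02 log units; within the scatter). Nothing here accounts for these results. Still open, on these data alone, is whether 4-cyanophenyl keeps its standing with methyl on the oxygen, and whether an amine on the aromatic ring would move the number.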